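The source may report more compounds than this note shows. Statements on the series, on what has been measured and on what is new or still open speak of the compounds shown alone.

Working notes on the series. The shared core carries a cyano group, an amino group and a 4-sulfamoylphenyl group; the compounds differ only at one saturated ring carbon. In a functional assay on Ehrlich cells (Mus musculus) for cytotoxicity, read by trypan blue exclusion, with a stated time of 2 h, tested at 25 ug/mL (on this read-out higher numbers stand for a stronger effect at the one concentration tested and lower numbers for a weaker effect), compound 2 `N#CC1=C(N)N(c2ccc(S(N)(=O)=O)cc2)C2=C(CCCC2)C1/C=C/c1ccccc1` gives 70%, the highest of the three numbers. Compound 1 `N#CC1=C(N)N(c2ccc(S(N)(=O)=O)cc2)C2=C(CCCC2)C1c1ccc(O)cc1` gives 42% and compound 3 `COc1ccccc1C1C(C#N)=C(N)N(c2ccc(S(N)(=O)=O)cc2)C2=C1CCCC2` gives 40%. The two steps that replace 2-phenylethenyl are a number 28 percentage points higher from compound 1 to compound 2 (beyond the scatter) read in reverse and a number 30 percentage points lower from compound 2 to compound 3 (beyond the scatter), both beyond the scatter, whereas a number 2 percentage points lower from compound 1 to compound 3 (within the scatter) stays within it. Compound 4 `N#CC1=C(N)N(c2ccc(S(N)(=O)=O)cc2)C2=C(CCCC2)C1c1cccs1` has not yet been measured. Its change from compound 2 is thiophen-2-yl in place of 2-phenylethenyl on a saturated ring carbon. Both measured replacements of 2-phenylethenyl on this saturated ring carbon gave a modest fall, and neither aryl group that entered differed from the other beyond the scatter. A step down of comparable size is therefore expected in this assay; the step expected from this change is a number 27 percentage points lower from compound 2 to compound 4 (beyond the scatter). For compound 4 the expected value is 43%, with a range of 30% to 58%.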

Compound 4, a percentage reported as activity, at one concentration (the size of the read-out at that concentration, not a potency): 5%
Compound 4: middle estimate off by 38 percentage points, on the high side, and the stated range ends above it.
By their numbers in this assay, from the lowest: compound 4; then compounds 3 and 1 (each within the scatter of the next); then compound 2.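

The position does not respond to aromatic groups as one class: in this assay thiophen-2-yl falls well short of both six-membered aryl groups (a number 37 percentage points lower from compound 1 to compound 4 (beyond the scatter); a number 35 percentage points lower from compound 3 to compound 4 (beyond the scatter)). The earlier agreement between 4-hydroxyphenyl and 2-methoxyphenyl therefore does not extend to every aromatic ring on this saturated ring carbon, and the step from 2-phenylethenyl (a number 65 percentage points lower from compound 2 to compound 4 (beyond the scatter)) is large, where the two earlier replacements were modest. No measured property is available to account for this fall.

On these data alone, it remains open whether the fall follows the sulfur atom or the five-membered ring, which a furan-2-yl or an unsubstituted phenyl group on this carbon would help to separate. Also open, as far as these compounds go, is whether the double bond of 2-phenylethenyl matters, which a 2-phenylethyl chain would test.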